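Removing a hydroxy group: expected effect on solubility

The source may hold more compounds than are shown below. What is called first, only, known or untested is meant among the compounds shown, and "the series" means these compounds.

Measured compounds:
Compound 1, `COc1cc2cc(C(=O)CC(O)C3CC[N+](C)(Cc4ccccc4)CC3)sc2cc1OC`: in a physicochemical assay for solubility (a lower number here means a less soluble compound, a higher number a more soluble compound), compound 1 gives 10000 ug/mL; 8000 ug/mL; 10000 ug/mL (3 entries).
Compound 2, `COc1cc2cc(C(=O)CC(O)CCC3CC[N+](C)(Cc4ccccc4)CC3)sc2cc1OC`: compound 2 gives 2500 ug/mL.
Compound 3, `COc1cc2cc(C(O)C3CC[N+](C)(Cc4ccccc4)CC3)sc2cc1OC`: compound 3 gives 2000 ug/mL.

All three compounds share the same core with a permanently charged nitrogen, and all are very soluble. Compound 1 has repeated entries, and the several entries of compound 1 in this assay, 10000 ug/mL; 8000 ug/mL; 10000 ug/mL (3 entries) shows how closely repeated measurements of this kind agree. Among the single numbers, the value of compound 3 and the value of compound 2 lie within the scatter of each other, so nothing separates them; the entries of compound 1 sit well above both.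

Compound 4, `COc1cc2cc(CC3CC[N+](C)(Cc4ccccc4)CC3)sc2cc1OC`, has not yet been measured in this assay. It differs from compound 3 in one place: hydrogen in place of hydroxy on a saturated chain carbon bound to an aromatic carbon and a saturated ring carbon. Among the measured compounds shown here, no measured pair in this set shows the same change, so its effect must be guessed. A small downward step is expected, one that may not rise above the usual scatter, since the charged group that dominates these molecules is kept.

Compound 4 is therefore expected to give about 1200 ug/mL, with a likely range from 400 ug/mL to 3000 ug/mL, a step of a 1.7-fold lower number from compound 3 to compound 4 (0.22 log units; within the scatter).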

Compound 4, solubility: 3000 ug/mL
Beside the measured number, compound 4's estimate is 2.5-fold (0.40 log units) below it, and the stated range covers the measured number.
By their numbers in this assay, from the lowest: compounds 3, 2 and 4 (each within the scatter of the next).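

In this assay, replacing hydroxy with hydrogen on a saturated chain carbon bound to an aromatic carbon and a saturated ring carbon gives a 1.5-fold higher number from compound 3 to compound 4 (0.18 log units; within the scatter). Among the compounds shown here, this is the first direct look at this change at this position, and the numbers do not separate the compound that carries the hydroxy from the one that lacks it, even though one hydrogen-bond donor and one hydrogen-bond acceptor leave with that group. The size of such a step can be set against how repeated readings of a single compound spread, as seen in the one compound with repeats: the several entries of compound 1 in this assay, 10000 ug/mL; 8000 ug/mL; 10000 ug/mL (3 entries)

Going by these compounds, whether an amine or a carboxylic acid on this same carbon would give a number clearly apart from those of compound 3 and compound 4 remains open. Also open, on these data alone, is whether the same exchange of hydroxy for hydrogen on the chains of compound 1 and compound 2 would likewise stay within the scatter, as this single pair speaks only for its own position.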